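The compounds below may be only part of what the source reports. "The series", "measured", "known", "first", "only" and "open" are said of these compounds alone.

Measured compounds:
- compound 1, `CCS(=O)(=O)Nc1cc(-c2ccc3ncnc(Nc4cccc(F)c4)c3c2)cnc1OC`: in a functional assay on SK-HEP1 cells (Homo sapiens) for cytotoxicity, read by sulforhodamine B assay, with a stated time of 72 h (a higher number here means a weaker inhibitor, a lower number a stronger inhibitor), compound 1 gives 1850 nM
- compound 2, `CCS(=O)(=O)Nc1cc(-c2ccc3ncnc(Nc4ccc(OC)cc4)c3c2)cnc1OC`: in this assay compound 2 gives 1610 nM

The two numbers sit close together: the step of a 1.1-fold lower number from compound 1 to compound 2 (0.06 log units; within the scatter) keeps compound 2 within the scatter of compound 1, so neither compound can be called the stronger of the pair. Compound 2 is the point of departure for compound 3, `CCS(=O)(=O)Nc1cc(-c2ccc3ncnc(Nc4ccc(OC)c(OC)c4)c3c2)cnc1OC`. The change is methoxy in place of hydrogen on an aromatic carbon, that is, 4-methoxyphenyl becomes 3,4-dimethoxyphenyl on the nitrogen of the shared core. Going by the values given here, only one measured step bears on this part of the molecule, the step of a 1.1-fold lower number from compound 1 to compound 2 (0.06 log units; within the scatter), which swapped one substituted phenyl ring for another and left the readout essentially unchanged. Among the compounds with values here, no step adds a second methoxy group to a ring already carrying one, so the effect of that addition is unknown from these data. Given that the one neighbouring step stayed within the scatter, compound 3 is expected to show a step of a 1.1-fold lower number from compound 2 to compound 3 (0.03 log units; within the scatter), with no movement beyond the scatter in either direction. Compound 3 is therefore estimated at 1500 nM, with a range from 600 nM to 3800 nM.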

Compound 3, half-maximal inhibitory concentration: 2840 nM
Estimate against measurement, compound 3: 1.9-fold (0.28 log units) below; the measured number falls inside the stated range.
By their numbers in this assay, from the lowest: compounds 2, 1 and 3 (each within the scatter of the next).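

In this assay, going by these compounds alone, the step for methoxy in place of hydrogen on an aromatic carbon, ortho to the methoxy group already on the ring, is a 1.8-fold higher number from compound 2 to compound 3 (0.25 log units; within the scatter) and gives the first direct reading of this change on a ring that already carries a methoxy group. Compared with the 3-fluorophenyl ring on the nitrogen, the 3,4-dimethoxyphenyl ring gives a 1.5-fold higher number from compound 1 to compound 3 (0.19 log units; within the scatter), so this comparison also stays within the usual scatter. Within these three compounds, the aryl group on the nitrogen has been varied without any step that lies beyond the scatter, so neither the added methoxy group nor the swap from 3-fluorophenyl can be said to shift the cytotoxicity readout.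

As far as these compounds go, it remains open whether a hydroxy group, an ethoxy group, a chlorine atom or a dimethylamino group on that same aromatic carbon would move the number beyond the scatter, and whether a 3-methoxyphenyl ring on the nitrogen would read differently from the 3,4-dimethoxyphenyl ring. Nothing in the available data offers an explanation for the readings of these compounds.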